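The source may report more compounds than this note shows. Statements on the series, on what has been measured and on what is new or still open speak of the compounds shown alone.

In a functional assay on M21 cells (Homo sapiens) for antiproliferative activity, read by sulforhodamine B assay, with a stated time of 48 h (a higher number here means a weaker inhibitor, a lower number a stronger inhibitor), compound 1 `CCCC(=O)Nc1cccc(S(=O)(=O)Oc2ccccc2C(C)C)c1` gives 20000 nM, compound 2 `CCC(=O)Nc1ccc(S(=O)(=O)Oc2ccccc2C(C)C)cc1` gives 11000 nM, and compound 3 `CCC(=O)Nc1ccc(S(=O)(=O)Oc2ccccc2I)cc1` gives 11000 nM. Compound 3 thus stands level with compound 2, the two together holding the lowest of the three numbers, while compound 1 sits within the scatter of both. Among the compounds with values here, the only single-point change measured so far, no change at the digits printed from compound 2 to compound 3 (within the scatter), exchanged a group on an aromatic carbon and moved nothing beyond the scatter.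

Compound 4 `CCNC(=O)Nc1ccc(S(=O)(=O)Oc2ccccc2I)cc1` differs from compound 3 at the amide end of the molecule: ethylamino in place of ethyl on a carbonyl carbon. Within the data shown here, no measured step touches this part of the structure, so the one step on record bears on it only by showing how flat this small series has been, with all three numbers lying within the scatter of one another. On that basis a step of no size beyond the scatter is expected from compound 3 to compound 4, that is no change at the digits printed from compound 3 to compound 4 (within the scatter). Compound 4 is therefore estimated at 11000 nM in this assay, with a range from 5000 nM to 25000 nM.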

Compound 4, half-maximal inhibitory concentration: 5600 nM
Compound 4: middle estimate off by 2.0-fold (0.29 log units), on the high side; measured number inside the range.
By their numbers in this assay, from the lowest: compounds 4, 2, 3 and 1 (each within the scatter of the next, the first and the last beyond it).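

Within the data shown here, the first change at the amide end of the molecule, ethylamino in place of ethyl on a carbonyl carbon, gives in this assay a 2.0-fold lower number from compound 3 to compound 4 (0.29 log units; within the scatter) and so stays within the scatter, like the earlier change on the aromatic carbon. This position therefore accepts propanoylamino changing to (ethylcarbamoyl)amino, with the entering group carrying a hydrogen-bond donor that ethyl lacks, without a step beyond the scatter in this assay. No independent measurement bears on how this change acts on the cells.

The compounds shown leave open whether a longer chain, such as butylamino, or a ring-bearing group, such as phenylamino, on the same carbonyl carbon would move the number beyond the scatter. They also leave open whether ethylamino would give a similar result with isopropyl in place of iodo.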